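Swapping a Propargyl Sulfide for a Chlorobenzyl Sulfide

The source may hold more compounds than are shown below. What is called first, only, known or untested is meant among the compounds shown, and "the series" means these compounds.

Compound 3 `C#CCSc1nnc(CCC)n1N1C(=O)c2ccccc2C1=O` carries a propargylsulfanyl group on a shared core. In a functional assay on HepG2 cells (Homo sapiens) for cytotoxicity, read by MTT assay, with a stated time of 48 h (a lower number here means a stronger inhibitor, a higher number a weaker inhibitor), compound 3 gives > 200000 nM, which is a limit of the assay and not a number. Its two measured relatives end the same way. Compound 1 `C=CCSc1nnc(CCC)n1N1C(=O)c2ccccc2C1=O` gives > 200000 nM in this assay, also a limit. Compound 2 `CCCc1nnc(SCC(=O)c2ccc(Cl)cc2)n1N1C(=O)c2ccccc2C1=O` gives > 200000 nM in this assay, again a limit. Among the measured compounds shown here, because every value so far sits at the limit of > 200000 nM in this assay, at which 3 of the 3 values shown sit, none of the steps joining these compounds can be read: a step that the two limits leave unreadable from compound 1 to compound 2, a step that the two limits leave unreadable from compound 1 to compound 3 and a step that the two limits leave unreadable from compound 2 to compound 3 all remain of unknown size, so nothing is known about how changing the group on the sulfur-bound chain carbon moves cytotoxicity here.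

Compound 4 `CCCc1nnc(SCc2ccccc2Cl)n1N1C(=O)c2ccccc2C1=O` differs from compound 3 by 2-chlorophenyl in place of ethynyl on a saturated chain carbon bound to a sulfur. For the measured compounds named here, no measured step offers a readable size for such a change, so the expectation rests only on the three limits already seen. Compound 4 is therefore expected to show no step beyond the scatter, a step that the limit leaves unreadable from compound 3 to compound 4, and most likely another limit. The estimate for compound 4 is 250000 nM, with a range from 60000 nM to 1000000 nM.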

Compound 4, half-maximal inhibitory concentration: > 200000 nM
Compound 4: only a limit was reported; the forecaster's own chance of this, stated with the estimate: 75%; the middle value is on the limit's open side.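

Compound 4 also ends at a limit of the assay, so its steps to compound 1, compound 2 and compound 3 cannot be read: the limit of > 200000 nM in this assay, at which 4 of the 4 values shown sit. The compounds shown leave open whether any group on a saturated chain carbon bound to a sulfur changes the result in this assay.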